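This account rests on a few compounds, and the source may have more. Where it says the series, first, only, none or still open, it means among the compounds named here.

Measured compounds:
- compound 1 `COCc1ccccc1Cc1cnc(N)nc1N`, 39800 nM
- compound 2 `Nc1ncc(Cc2ccccc2Br)c(N)n1`, 12300 nM

In an assay for inhibition of Dihydrofolate reductase (Gallus gallus) (a lower number here means a stronger inhibitor, a higher number a weaker inhibitor), compound 2 stands at the lowest of the two numbers; the nearest is compound 1, with the step of a 3.2-fold lower number from compound 1 to compound 2 (0.51 log units; beyond the scatter). The unmeasured compound 3 `Nc1ncc(Cc2ccccc2Cl)c(N)n1` differs from compound 2 by chloro in place of bromo on an aromatic carbon, on an aromatic carbon of a six-membered aromatic ring of carbon only.

Among the compounds with values here, no measured step exchanges one halogen for another; the only step at hand, a 3.2-fold lower number from compound 1 to compound 2 (0.51 log units; beyond the scatter), replaces a methoxymethyl and does not bear directly on this change. A step within the scatter is therefore expected, a 1.3-fold higher number from compound 2 to compound 3 (0.11 log units; within the scatter). For compound 3 the estimate is 16000 nM, range 6000 nM to 45000 nM.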

Compound 3, inhibition constant: 17400 nM
Compound 3: middle estimate off by 1.1-fold (0.04 log units), on the low side; low and high end bracket the measured number.
By their numbers in this assay, from the lowest: compounds 2 and 3 (each within the scatter of the next); then compound 1.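

In this assay, within the data shown here, the one halogen exchange at this position gives a 1.4-fold higher number from compound 2 to compound 3 (0.15 log units; within the scatter) and so does not separate chloro from bromo. Chloro also keeps an advantage over methoxymethyl, with a 2.3-fold lower number from compound 1 to compound 3 (0.36 log units; beyond the scatter), so the difference from compound 1 is not confined to bromo. No measurement shown here accounts for either step.

Still open, going by these compounds, is whether fluoro, methyl or an amine on this aromatic carbon would read like the two halogens or like methoxymethyl. On these data alone, a longer ether chain in place of methoxymethyl also remains untested in these compounds.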